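Trimming a Methyl Next to the Amide in Two Alkynes

The source may hold more compounds than are shown below. What is called first, only, known or untested is meant among the compounds shown, and "the series" means these compounds.

Measured so far:
compound 1 `C[C@@H](NC(=O)c1ccc(C#Cc2ccccc2F)cn1)C(C)(C)O`, 29.6%
compound 2 `C[C@@H](NC(=O)c1ccc(C#Cc2cccc(F)c2)cn1)C(C)(C)C`, 31.2%

In an ADME assay on HEK293 cells for agonist activity at metabotropic glutamate receptor 5 (Rattus norvegicus), read by fluorescence and calcium flux (a higher number here means a larger maximal response, a lower number a smaller maximal response), compound 2 gives 31.2%, the higher of the two numbers, though compound 1 at 29.6% lies within the scatter of it. Compound 3 `CC(C)(C)CNC(=O)c1ccc(C#Cc2cccc(F)c2)cn1` carries hydrogen in place of methyl on a saturated chain carbon bound to an amide-type nitrogen and a saturated chain carbon. Within the data shown here, no measured pair shows this change, so its effect is unknown; a step of no more than the scatter, in either direction, is expected from compound 2 to compound 3. The step of a number 1.2 percentage points lower from compound 2 to compound 3 (within the scatter) is the estimate made here. For compound 3 the expected value is 30%, with a range from 15% to 45%.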

Compound 3, largest response reached (reported as efficacy), in percent of the reference or control that the assay uses: 9.5%
Estimate against measurement, compound 3: 20.5 percentage points above; the measured number lies below the stated range.
By their numbers in this assay, from the lowest: compound 3; then compounds 1 and 2 (each within the scatter of the next).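

In this assay, the change from 1,2,2-trimethylpropyl to neopentyl gives a number 21.7 percentage points lower from compound 2 to compound 3 (beyond the scatter). This is the only pair shown that differs in one place, and it shows that a single methyl on this saturated chain carbon, bound to an amide-type nitrogen and a saturated chain carbon, can separate two compounds by more than the scatter. Nothing measured here accounts for the size of this step. The compounds shown leave open whether an ethyl group or a longer chain on this carbon would keep the maximal response. As far as these compounds go, whether the same replacement by hydrogen would lower the number for compound 1 also remains open.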